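Swapping the Aryl Sulfone for a Benzyl Sulfone

The compounds below may be only part of what the source reports. "The series", "measured", "known", "first", "only" and "open" are said of these compounds alone.

Compounds measured so far:
compound 1, `Cn1c(=O)c(S(=O)(=O)c2ccccc2)cc2cnc(Nc3ccc4cc[nH]c4c3)nc21`, giving 10000 nM;
compound 2, `Cn1c(=O)c(S(=O)(=O)c2ccc(F)cc2[N+](=O)[O-])cc2cnc(Nc3ccc4[nH]ccc4c3)nc21`, giving 1500 nM;
compound 3, `Cn1c(=O)c(S(=O)(=O)c2ccc(F)cc2F)cc2cnc(Nc3ccc4[nH]c(C(=O)O)cc4c3)nc21`, giving 10000 nM.

All three were tested in a functional assay on DU-145 cells (Homo sapiens) for inhibition, read by trypan blue exclusion, with a stated time of 72 h; a lower number here means a stronger inhibitor, a higher number a weaker inhibitor. Among these three numbers compound 2 holds the lowest; compound 1 sits well beyond the scatter from it, as does compound 3. Compound 2 is therefore the strongest of the three compounds on this read-out.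

The new compound 4, `Cn1c(=O)c(S(=O)(=O)Cc2ccc(F)cc2)cc2cnc(Nc3ccc4[nH]ccc4c3)nc21`, differs from compound 2 in one place: 4-fluorobenzyl in place of 4-fluoro-2-nitrophenyl on a sulfonyl sulfur. The aromatic ring that carried a nitro group leaves, and a 4-fluorobenzyl group, with no hydrogen-bond acceptors at all, enters on the sulfonyl sulfur.

Within the data shown here, no measured pair shows this exact change, so the size of the step is uncertain. Compound 1 and compound 3, which also lack the nitro-bearing ring of compound 2, both give weaker values, so a step toward a weaker inhibitor is expected, from compound 2 to compound 4 of about a 2.7-fold higher number from compound 2 to compound 4 (0.43 log units; beyond the scatter). Compound 4 is estimated at 4000 nM, within a range from 1000 nM to 15000 nM.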

Compound 4, half-maximal inhibitory concentration: 30000 nM
For compound 4 the middle estimate is 7.5-fold (0.88 log units) below the measured one; the whole stated range lies below it.
By their numbers in this assay, from the lowest: compound 2; then compounds 1 and 3 (each within the scatter of the next); then compound 4.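

In this assay, putting 4-fluorobenzyl in place of 4-fluoro-2-nitrophenyl on the sulfonyl sulfur gives a 20-fold higher number from compound 2 to compound 4 (1.30 log units; beyond the scatter), a large step. Among these compounds, the earlier compounds differ from one another in more than one place, so this pair is the first to show that the group on this sulfur alone can move the number well beyond the scatter. The change is not a single edit, however: the nitro group leaves, and the aromatic ring is no longer bonded directly to the sulfur but held through a carbon link.

Going by these compounds, a 4-fluorophenyl or a 4-fluoro-2-nitrobenzyl group on the same sulfur would help separate these two differences, so which of them matters stays open. Nothing available here explains the size of this step.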